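The source may report more compounds than this note shows. Statements on the series, on what has been measured and on what is new or still open speak of the compounds shown alone.

Compound 1 `COc1cc2c(Oc3ccc(NC(=O)c4cc(-c5ccccc5)nc5ccccc45)cc3F)ccnc2cc1OCCCN1CCCCC1` is the starting point of this comparison. In a functional assay on MKN-45 cells (Homo sapiens) for cytotoxicity, read by MTT assay, with a stated time of 72 h (a higher number here means a weaker inhibitor, a lower number a stronger inhibitor), compound 1 gives 15 nM. Going by the values given here, its only measured neighbour is compound 2 `COc1cc2c(Oc3ccc(NC(=O)c4cc(-c5cccc(Cl)c5)nc5ccccc45)cc3F)ccnc2cc1OCCCN1CCCCC1`, which in this assay gives 11 nM. The two differ by a chloro in place of hydrogen on an aromatic carbon, and the step of a 1.4-fold lower number from compound 1 to compound 2 (0.13 log units; within the scatter) is too small to count as a real change, so compound 1 simply stands at the higher of two numbers that sit within the usual scatter of each other.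

Compound 3 `COc1cc2c(Oc3ccc(NC(=O)c4cc(-c5ccccc5)nc5ccc(F)cc45)cc3F)ccnc2cc1OCCCN1CCCCC1` is not yet measured. It differs from compound 1 by fluoro in place of hydrogen on an aromatic carbon. Among the compounds with values here, the one measured step that bears on this is the step from compound 1 to compound 2, where a halogen replaced a hydrogen on an aromatic carbon without moving the number beyond the scatter. On that basis, a small halogen added to compound 1 is expected to leave this assay close to where it is, with no step beyond the scatter, as no change at the digits printed from compound 1 to compound 3 (within the scatter) expresses. Compound 3 is therefore estimated at 15 nM, with a range from 6 nM to 40 nM.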

Compound 3, half-maximal inhibitory concentration: 30 nM
Compound 3: the middle estimate sits 2.0-fold (0.30 log units) below what was measured; the range from low to high includes it.
By their numbers in this assay, from the lowest: compounds 2, 1 and 3 (each within the scatter of the next, the first and the last beyond it).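

The step to fluoro, a 2.0-fold higher number from compound 1 to compound 3 (0.30 log units; within the scatter), means that in this assay this carbon of the fused two-ring system takes a fluoro in place of hydrogen without a change that can be called real, although one pair of values gives only a thin reading. The earlier step placed a chloro on a different ring, so a halogen has now been tried at two separate places on the core of compound 1, and neither step lies beyond the scatter. No measurement offered here explains why either halogen leaves the number within the scatter.

The compounds shown leave open what a group other than fluoro would do at this same carbon, such as an amine, a carboxylic acid or a longer chain like a propoxy group. They also leave open whether the other free carbons of this ring behave like this one, and whether a fluoro here and a chloro on the other ring, placed together in one compound, would stay within the scatter of compound 1.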